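This account rests on a few compounds, and the source may have more. Where it says the series, first, only, none or still open, it means among the compounds named here.

Working notes on the series. Three compounds built on the shared core have a number in an assay on mitochondria from L6 cells (Rattus norvegicus) for activation, with a stated time of 90 min; a higher number here means that more compound is needed for the effect, a lower number that less compound is needed. Compound 1 `FC(F)(F)c1cccc(Nc2nc3nonc3nc2Nc2cccc(C(F)(F)F)c2)c1` gives 700 nM in this assay. Compound 2 `FC(F)(F)Oc1ccc(Nc2nc3nonc3nc2Nc2ccc(OC(F)(F)F)c(Br)c2)cc1Br` gives 2200 nM in this assay. Compound 3 `Fc1ccc(Nc2nc3nonc3nc2Nc2ccccc2F)c(F)c1` gives 300 nM in this assay, the lowest of the three numbers; its gap to compound 1 and its wider gap to compound 2 both lie beyond the usual scatter, so of these three compound 3 needs the least compound for the effect. With three points no pattern is claimed.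

Compound 4 `Fc1ccccc1Nc1nc2nonc2nc1Nc1ccccn1` has not yet been measured. It differs from compound 3 in one place: pyridin-2-yl in place of 2,4-difluorophenyl on a nitrogen on an aromatic ring. Within the data shown here, no two measured compounds differ in a single place, so no step of this kind has a precedent in this assay, and the size of the step is uncertain. The expectation is a step in this assay of small size, most likely within the scatter, with a slight lean toward a higher number for compound 4 than compound 3 shows at 300 nM. Compound 4 is expected to give about 450 nM in this assay, within a range of 130 nM to 1600 nM. The expected step is a 1.5-fold higher number from compound 3 to compound 4 (0.18 log units; within the scatter).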

Compound 4, half-maximal effective concentration: 9000 nM
Estimate against measurement, compound 4: 20-fold (1.30 log units) below; measured number above the stated range.
By their numbers in this assay, from the lowest: compound 3; then compound 1; then compound 2; then compound 4.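

In this assay, among these compounds, the exchange of 2,4-difluorophenyl for pyridin-2-yl gives a 30-fold higher number from compound 3 to compound 4 (1.48 log units; beyond the scatter) and this large step is the first single-place comparison, since none of the earlier compounds differed from another in only one place. It shows that this place, on a nitrogen on an aromatic ring, is not indifferent to the group it carries, even when a six-membered aromatic ring stays in place. The change is also a double one: a ring of carbon only bearing two fluorines leaves, and a ring with one nitrogen and no fluorine enters, so the step belongs to the exchange as a whole and not to either part. No measurement at hand bears on what lies behind the step.

From the compounds shown here alone, whether the loss of the fluorines or the entry of the ring nitrogen carries the step stays open, and a plain phenyl or a pyridin-3-yl in this place would be needed to separate the two. Also open, going by these compounds, is how the pyridin-2-yl ring would respond to a further group on it, such as an amine or a carboxylic acid.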